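Swapping the fluorophenyl ring of compound 3 for a furan

The compounds below may be only part of what the source reports. "The series", "measured", "known", "first", "only" and "open" are said of these compounds alone.

Of the compounds shown here, three sharing one core have been measured in an assay on membranes from Sf9 cells for displacement of a labelled ligand from histamine H2 receptor (Homo sapiens), read by scintillation counting, with a stated time of 60 min; a lower number here means a stronger inhibitor, a higher number a weaker inhibitor. Compound 1 `Cc1nc(N)sc1CCCN/C(N)=N/C(=O)N[C@@H](C)c1ccccc1` gives 51.3 nM in this assay. Compound 2 `Cc1nc(N)sc1CCCN/C(N)=N/C(=O)NCc1ccccc1` gives 69.2 nM in this assay. Compound 3 `Cc1nc(N)sc1CCCN/C(N)=N/C(=O)NC(C)c1ccc(F)cc1` gives 31.6 nM in this assay, the lowest of the three numbers, though its gap to compound 1 lies within the scatter and only its gap to compound 2 lies beyond it.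

Compound 4 `Cc1nc(N)sc1CCCN/C(N)=N/C(=O)NC(C)c1ccco1` differs from compound 3 by furan-2-yl in place of 4-fluorophenyl on a saturated chain carbon bound to an amide-type nitrogen and a saturated chain carbon. Within the data shown here, the only measured step, a 1.3-fold higher number from compound 1 to compound 2 (0.13 log units; within the scatter), concerns the saturated carbon next to the nitrogen, not the ring, so no measured step bears directly on this change. Among the measured compounds shown here, the furan ring is smaller and carries one acceptor, but the data give no step that shows what such a swap does in this assay.

In this assay compound 4 is therefore expected to give 60 nM, within a range from 20 nM to 180 nM. This estimate means a step of a 1.9-fold higher number from compound 3 to compound 4 (0.28 log units; within the scatter), which is expected to stay close to the scatter.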

Compound 4, inhibition constant: 31.6 nM
Beside the measured number, compound 4's estimate is 1.9-fold (0.28 log units) above it, within the range that was stated.
By their numbers in this assay, from the lowest: compounds 3, 4, 1 and 2 (each within the scatter of the next, the first and the last beyond it).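

On the saturated chain carbon bound to an amide-type nitrogen and a saturated chain carbon, furan-2-yl stands in for 4-fluorophenyl with no change at the digits printed from compound 3 to compound 4 (within the scatter) in this assay, although the entering group has fewer heavy atoms and one hydrogen-bond acceptor where the leaving group has none. The 1-(furan-2-yl)ethyl group also shows a 1.6-fold lower number from compound 1 to compound 4 (0.21 log units; within the scatter) when it replaces 1-phenylethyl, and a 2.2-fold lower number from compound 2 to compound 4 (0.34 log units; beyond the scatter) when it replaces benzyl, so only the comparison with benzyl goes beyond the scatter. No measurement offered here gives a reason for these results.

The compounds shown leave open whether an aromatic ring is needed on this carbon at all. Going by these compounds, how a dimethylamino group or a butyl chain in its place would read in this assay also remains open.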